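A few compounds are considered here, and "the series" means these few. Any claim that something is new, unique, unknown or untested is made for them only; others in the source may bear on it.

Measured in a functional assay on HepG2 cells (Homo sapiens) for antiproliferative activity, read by MTT assay, with a stated time of 48 h; on this read-out higher numbers stand for weaker inhibition and lower numbers for stronger inhibition:
Compound 1 `CC(=O)N1N=C(c2ccc3ccccc3c2)OC1c1ccccc1`: 2.11 ug/mL
Compound 2 `CC(=O)N1N=C(c2ccc3ccccc3c2)OC1c1ccccc1Cl`: 4.32 ug/mL

Of these two, compound 2 holds the higher number, 4.32 ug/mL, which means the weaker inhibition in this assay. The next compound to be tested is compound 3 `CC(=O)N1N=C(c2ccc3ccccc3c2)OC1c1cccc(F)c1`. It keeps the shared core and differs from compound 2 in one group, with 3-fluorophenyl in place of 2-chlorophenyl on a saturated ring carbon.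

Going by the values given here, only one measured step bears on this change: a 2.0-fold higher number from compound 1 to compound 2 (0.31 log units; beyond the scatter). That step is modest, though beyond the scatter, and it came with chloro in place of hydrogen on an aromatic carbon. Compound 3 carries no chloro group, so its number may fall back part of the way toward that of compound 1. Among the compounds with values here, no measured compound carries a 3-fluorophenyl group, however, so this remains an uncertain guess. The expected change is small, a 1.4-fold lower number from compound 2 to compound 3 (0.16 log units; within the scatter), and it would not stand clear of the scatter. In this assay, compound 3 is estimated at 3 ug/mL, with an expected range of 1.3 ug/mL to 6.5 ug/mL.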

Compound 3, half-maximal inhibitory concentration: 1.86 ug/mL
Compound 3: the middle estimate sits 1.6-fold (0.21 log units) above what was measured, and the stated range covers the measured number.
By their numbers in this assay, from the lowest: compounds 3 and 1 (each within the scatter of the next); then compound 2.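

In this assay, 3-fluorophenyl in place of 2-chlorophenyl on the saturated ring carbon gives a 2.3-fold lower number from compound 2 to compound 3 (0.37 log units; beyond the scatter), so the modest loss seen with the chloro group in compound 2 is not shared by every halogen-bearing phenyl group at this position. Adding the fluoro group gives a 1.1-fold lower number from compound 1 to compound 3 (0.05 log units; within the scatter), which lies within the scatter, so compound 3 and compound 1 cannot be told apart here and this position tolerates the 3-fluorophenyl group without a measurable change in the number. No measurements are available that explain why the 2-chlorophenyl and 3-fluorophenyl groups give different numbers.

The change from compound 2 to compound 3 alters both the halogen and where it sits on the phenyl ring, so the compounds shown cannot say which of the two matters. They also leave open how this assay would respond to a non-halogen group on that phenyl ring, such as an amine or a carboxylic acid, or to a longer chain in place of the acetyl group.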